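The source may hold more compounds than are shown below. What is called first, only, known or untested is meant among the compounds shown, and "the series" means these compounds.

In an ADME assay on HUVEC cells (Homo sapiens) for inhibition, read by CCK-8 assay, with a stated time of 24 h, in the presence of a further agent that is not named here (a lower number here means a stronger inhibitor, a higher number a weaker inhibitor), compound 1 (`O=C1Nc2ccc(F)cc2/C1=C/c1ccc(-c2cn(-c3cccc(Cl)c3)nn2)cc1`) gives 19400 nM as a measured number. Compound 2 (`N#Cc1cccc(-n2cc(-c3ccc(/C=C4\C(=O)Nc5ccc(F)cc54)cc3)nn2)c1`) gives > 20000 nM in this assay and this is a limit of the assay, not a number. Compound 2 therefore has no exact position on the scale.

The next compound, compound 3 (`O=C1Nc2ccc(F)cc2/C1=C/c1ccc(-c2cn(-c3ccc(Cl)c(C(F)(F)F)c3)nn2)cc1`), differs from compound 2 at one place, with 4-chloro-3-(trifluoromethyl)phenyl in place of 3-cyanophenyl on an aromatic nitrogen (the rest of the structure is shared).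

Within the data shown here, only one measured step bears on this change. It is an at least 1.0-fold higher number from compound 1 to compound 2 (0.01 log units; that floor lies within the scatter) with cyano in place of chloro on an aromatic carbon. That step has only a floor, which lies within the scatter, and it exchanges a single group rather than the whole 3-cyanophenyl. It therefore gives no ground to expect a large move in either direction. The expected step is an at least 1.2-fold lower number from compound 2 to compound 3 (0.09 log units; that floor lies within the scatter) and no change beyond the scatter is expected. Compound 3 is estimated at 16000 nM with an expected range from 6000 nM to 30000 nM in this assay and it may also return only a limit.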

Compound 3, half-maximal inhibitory concentration: > 20000 nM
Compound 3: only a limit was reported; the forecaster's own chance of this, stated with the estimate: 45%; at least 1.2-fold (0.09 log units) between middle value and limit.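

Compound 3 is a second compound reported in this assay only as a limit, not as a number, so replacing 3-cyanophenyl with 4-chloro-3-(trifluoromethyl)phenyl on the aromatic nitrogen gives a step that cannot be read. With 3-chlorophenyl at this position as the reference, the one readable statement is an at least 1.0-fold higher number from compound 1 to compound 3 (0.01 log units; that floor lies within the scatter), and this sets no order between the two groups. The result therefore adds a second, differently substituted phenyl group at the same limit: the limit of > 20000 nM in this assay, at which 2 of the 3 values shown sit.

The compounds shown leave open whether a different kind of group on this nitrogen, such as a phenyl ring bearing a carboxylic acid or an amine, would give a clearly lower number in this assay. Every group shown is a substituted phenyl, and the size of any effect of changing this position, as well as the order of compound 2 and compound 3, remains unknown.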